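A few compounds are considered here, and "the series" means these few. Any claim that something is new, unique, unknown or untested is made for them only; others in the source may bear on it.

Compounds measured so far:
- compound 1 `COC(=O)C1(c2ccccc2)CC1CN1CCN(c2ncccn2)CC1`: 3090 nM
- compound 2 `COC(=O)C1(c2ccc(Cl)cc2)CC1CN1CCN(c2ncccn2)CC1`: 350 nM

The two compounds were tested in an assay for displacement of a labelled ligand from Sigma non-opioid intracellular receptor 1 (Cavia porcellus); a lower number here means a stronger inhibitor, a higher number a weaker inhibitor. Compound 2 gives 350 nM, the lower of the two numbers, and compound 1 gives 3090 nM. Going by the values given here, the only step between them, an 8.8-fold lower number from compound 1 to compound 2 (0.95 log units; beyond the scatter), shows that adding a chloro group at this position changed the number by a modest but real amount.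

Compound 3 `COC(=O)C1(c2ccc([N+](=O)[O-])cc2)CC1CN1CCN(c2ncccn2)CC1` has not yet been measured. It differs from compound 2 by nitro in place of chloro on an aromatic carbon. Among the compounds with values here, no measured step covers an exchange of one substituent for another at this position; the single known step only describes putting chloro in place of hydrogen. That step shows the position is sensitive to substitution, so some change from compound 2 is plausible, but its direction cannot be read off the data. The expectation for compound 3 is therefore a number not far from compound 2, with a slight lean toward a higher value, as a 2.3-fold higher number from compound 2 to compound 3 (0.36 log units; beyond the scatter). The estimate for compound 3 in this assay is 800 nM, within a range from 250 nM to 2500 nM.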

Compound 3, inhibition constant: 619 nM
Beside the measured number, compound 3's estimate is 1.3-fold (0.11 log units) above it; the measured number falls inside the stated range.
By their numbers in this assay, from the lowest: compounds 2 and 3 (each within the scatter of the next); then compound 1.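

In this assay, nitro in place of chloro gives a 1.8-fold higher number from compound 2 to compound 3 (0.25 log units; within the scatter), so the 4-chlorophenyl and 4-nitrophenyl compounds cannot be told apart here, although nitro has more heavy atoms and brings hydrogen-bond acceptors that chloro does not. Going by these compounds alone, measured against hydrogen at the same carbon, para to a large group, nitro gives a 5.0-fold lower number from compound 1 to compound 3 (0.70 log units; beyond the scatter), so the earlier step from hydrogen to chloro is no longer the only example: two different groups at this position each stand apart from hydrogen in the same direction. No measurement is available that explains why these two groups give matching results.

The compounds shown cover only hydrogen, chloro and nitro at this position, so it remains open whether an amine, a methoxy group or a carboxylic acid would match chloro and nitro or fall back towards hydrogen. As far as these compounds go, it also remains open whether the match between chloro and nitro would hold if another part of the shared core were changed.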